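This account rests on a few compounds, and the source may have more. Where it says the series, first, only, none or still open, it means among the compounds named here.

Measured so far in an assay on HEK293 cells for binding affinity to adenosine receptor A2b (Homo sapiens), read by radioligand binding; a higher number here means a weaker inhibitor, a lower number a stronger inhibitor:
compound 1 `CCn1c(=O)c2nc[nH]c2n(CC)c1=O`: 1770 nM
compound 2 `CC(=O)OCCn1cnc2c1c(=O)n(C)c(=O)n2C`: 23200 nM
compound 3 `Cn1c(=O)c2nc(-c3ccc([N+](=O)[O-])cc3)[nH]c2n(C)c1=O`: 6940 nM

Compound 3 stands second highest of the three numbers. The number for compound 2 is higher and the number for compound 1 lower, and each of these gaps lies beyond the usual scatter. Compound 4 `CN(C)c1ccc(-c2nc3c(=O)n(C)c(=O)n(C)c3[nH]2)cc1` is not yet measured. It differs from compound 3 by dimethylamino in place of nitro on an aromatic carbon. Among the measured compounds shown here, no measured pair shows that exchange, so its size is not known from the data. A modest move toward a lower number is expected, as a 2.3-fold lower number from compound 3 to compound 4 (0.36 log units; beyond the scatter), not a large one. Compound 4 is therefore estimated at 3000 nM in this assay, with a range from 600 nM to 15000 nM.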

Compound 4, inhibition constant: 289 nM
Compound 4: the middle estimate sits 10-fold (1.02 log units) above what was measured, and the stated range ends above it.
By their numbers in this assay, from the lowest: compound 4; then compound 1; then compound 3; then compound 2.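

In this assay, dimethylamino in place of nitro on the aromatic carbon para to a large group gives a 24-fold lower number from compound 3 to compound 4 (1.38 log units; beyond the scatter), with the rest of the molecule unchanged. Among the compounds shown here, this is the first single-place step, and it shows that the number responds strongly to the group at this position. Nothing measured here accounts for the size of this step.

On these data alone, it remains open whether the step comes from gaining dimethylamino or from losing nitro. A bare hydrogen, methoxy or diethylamino at this place would help to separate the two.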